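Chloro in place of methoxy: notes on compound 3

The compounds below may be only part of what the source reports. "The series", "measured", "known", "first", "only" and "open" are said of these compounds alone.

Measured values in a functional assay on MDA-MB-231 cells (Homo sapiens) for inhibition, with a stated time of 72 h (on this read-out lower numbers stand for stronger inhibition and higher numbers for weaker inhibition), for the two compounds so far
- compound 1 `COc1ccc(NC(=O)Nc2nc(Sc3c[nH]c4ccccc34)cc(N3CCCCC3)n2)cc1` at 7260 nM
- compound 2 `COc1ccc(NC(=O)Nc2nc(Nc3cc(OC)cc(OC)c3)cc(Sc3c[nH]c4ccccc34)n2)cc1` at 9460 nM

Within the data shown here, only one step has been measured, and it reads a 1.3-fold higher number from compound 1 to compound 2 (0.11 log units; within the scatter) which places compound 1 level with the other measured compound. Compound 3 `O=C(Nc1ccc(Cl)cc1)Nc1nc(Sc2c[nH]c3ccccc23)cc(N2CCCCC2)n1` is the next case. Its difference from compound 1 is chloro in place of methoxy on an aromatic carbon with 4-methoxyphenyl becoming 4-chlorophenyl. The measured step lies elsewhere, with (3,5-dimethoxyphenyl)amino in place of piperidin-1-yl, so it bears on this change only indirectly. Among the measured compounds shown here, no measured pair varies the 4-methoxyphenyl group itself. No step beyond the scatter is therefore expected in this assay and no firm direction can be argued. The expected step is a 1.2-fold lower number from compound 1 to compound 3 (0.08 log units; within the scatter) in this estimate. Compound 3 is estimated at 6000 nM within a range of 2500 nM to 14000 nM until a measurement is available.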

Compound 3, half-maximal inhibitory concentration: 10100 nM
Beside the measured number, compound 3's estimate is 1.7-fold (0.23 log units) below it; the range from low to high includes it.
By their numbers in this assay, from the lowest: compounds 1, 2 and 3 (each within the scatter of the next).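

In this assay the one pair shown that varies the 4-methoxyphenyl group gives a 1.4-fold higher number from compound 1 to compound 3 (0.14 log units; within the scatter) at this site, so chloro and methoxy cannot be told apart on this read-out. In this pair, the position para to a large group therefore keeps the number within the scatter when the methoxy, with its hydrogen-bond acceptor, leaves and chloro enters. No measurement on hand accounts for this outcome.

On these data alone, with a single pair at this position, it remains open whether any group placed there can move the number beyond the scatter. A carboxylic acid, a dimethylamino group or a longer alkoxy chain in the same place, with the rest of compound 1 kept, would show how far this insensitivity extends.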